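The source may hold more compounds than are shown below. What is called first, only, known or untested is meant among the compounds shown, and "the series" means these compounds.

Of the compounds shown here, three have been measured so far in an ADME assay on HEp-2 cells (Homo sapiens) for cytotoxicity, with a stated time of 4 days (a lower number here means that less compound is tolerated, a higher number that more compound is tolerated), and each result is a limit of the assay rather than a number.

Compound 1 `CS(=O)(=O)CCCn1c(Cn2cc(S(C)(=O)=O)c3ccncc32)nc2cc(Cl)ccc21` gives > 100000 nM in this assay, a limit.
Compound 2 `CS(=O)(=O)CCCn1c(Cn2nc(S(C)(=O)=O)c3ccccc32)nc2cc(Cl)ccc21` gives > 100000 nM in this assay, a limit.
Compound 3 `CS(=O)(=O)c1nn(Cc2nc3cc(Cl)ccc3n2CCO)c2cnccc12` gives > 100000 nM in this assay, a limit.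

So compound 3 stands where every measured compound stands: at the upper edge of what this assay reports, as the limit of > 100000 nM in this assay, at which 3 of the 3 values shown sit, shows, and no measured step between compounds is available to show how any change in structure moves the result.

Compound 4 `CC(C)(O)CCn1c(Cn2nc(S(C)(=O)=O)c3ccncc32)nc2cc(Cl)ccc21` differs from compound 3 in one place: 1-hydroxy-1-methylethyl in place of hydroxy on a saturated chain carbon, two bonds along the chain from an aromatic nitrogen. Cut one bond further out, the same difference reads hydroxymethyl to 2-hydroxy-2-methylpropyl, or 2-hydroxyethyl to 3-hydroxy-3-methylbutyl.

With all three measured values sitting at the limit, the expected step of a number no higher from compound 3 to compound 4 (the limit leaves the size open) is none beyond the usual scatter, in either direction. Compound 4 is therefore estimated at 100000 nM in this assay, within a range from 50000 nM to 300000 nM, most likely reported again as a limit.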

Compound 4, half-maximal cytotoxic concentration: > 100000 nM
Compound 4: no number, only a limit (the forecaster's own chance of this, stated with the estimate: 85%); the middle value sits exactly at the limit.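

No step from compound 3 to compound 4 can be read in this assay, because both results are limits and not numbers: the limit of > 100000 nM in this assay, at which 4 of the 4 values shown sit.

Whether 1-hydroxy-1-methylethyl in place of hydroxy, or any other change among the compounds shown, moves the tolerated concentration at all stays open.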